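The source may report more compounds than this note shows. Statements on the series, on what has been measured and on what is new or still open speak of the compounds shown alone.

Compound 1 `CCOCC(=O)OCCc1c(-c2ccccc2Cl)c2cc(Cl)ccc2[nH]c1=O` gives 130000 nM in an ADME assay on HepG2 2.2.15 cells (Homo sapiens) for cytotoxicity; on this read-out higher numbers stand for lower toxicity in this test and lower numbers for higher toxicity in this test.
Compound 2 `O=C(OCCc1c(-c2ccccc2Cl)c2cc(Cl)ccc2[nH]c1=O)C1CCCCC1` gives 38000 nM in this assay.

Of these two numbers, compound 2 stands lowest. For the measured compounds named here, its only neighbour is compound 1, and the step of a 3.4-fold lower number from compound 1 to compound 2 (0.53 log units; beyond the scatter) separates them, a change beyond the usual scatter of this assay.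

Compound 3 `C/C=C(\C)C(=O)OCCc1c(-c2ccccc2Cl)c2cc(Cl)ccc2[nH]c1=O` has not yet been measured. It differs from compound 2 in one place: 1-methylprop-1-en-1-yl in place of cyclohexyl on a carbonyl carbon. Going by the values given here, only one measured step bears on this position, a 3.4-fold lower number from compound 1 to compound 2 (0.53 log units; beyond the scatter), and it shows that exchanging the group on the carbonyl carbon can shift the number by a modest amount that is still beyond the scatter. Among the compounds with values here, no measured compound carries the 1-methylprop-1-en-1-yl group, so the direction of the coming step is uncertain. Since the group that leaves is the one that brought the lowest number, a partial return toward the number of compound 1 is expected, and the step from compound 2 to compound 3 is estimated as a 1.6-fold higher number from compound 2 to compound 3 (0.20 log units; within the scatter). Compound 3 is therefore expected to give about 60000 nM in this assay, with a likely range from 25000 nM to 150000 nM.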

Compound 3, half-maximal cytotoxic concentration: 350000 nM
Beside the measured number, compound 3's estimate is 5.8-fold (0.77 log units) below it; measured number outside the range, above it.
By their numbers in this assay, from the lowest: compound 2; then compound 1; then compound 3.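

In this assay, the group on the carbonyl carbon can move the number much further than the first pair suggested: 1-methylprop-1-en-1-yl in place of cyclohexyl gives a 9.2-fold higher number from compound 2 to compound 3 (0.96 log units; beyond the scatter). The new group does not merely restore the level set by ethoxymethyl but passes it, with a 2.7-fold higher number from compound 1 to compound 3 (0.43 log units; beyond the scatter), so the order of these three compounds places the group with the double bond at the least toxic end in this test and the cyclohexyl group, the only one of the three with a ring, at the most toxic end. Nothing measured here accounts for this order, and no independent data on these groups are available to explain it.

The change from cyclohexyl to 1-methylprop-1-en-1-yl removes the ring, shortens the group from six carbons to four and adds a double bond all at once, so these compounds cannot show which of those differences matters. A saturated sec-butyl group and a smaller cyclobutyl ring on the same carbonyl carbon would pull these differences apart, while an amine in this position remains an entirely open case.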